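Adding One Methyl to the Ketone Chain of Compound 1

The source may hold more compounds than are shown below. What is called first, only, known or untested is meant among the compounds shown, and "the series" means these compounds.

Of the compounds shown here, three have been measured in an assay on HEK293 cells for positive allosteric modulation of metabotropic glutamate receptor 3 (Rattus norvegicus), read by thallium flux, with a stated time of 2.5 min; a higher number here means that more compound is needed for the effect, a lower number that less compound is needed. Compound 1 `COc1cc(C(=O)O)ccc1OCCCCOc1ccc(C(=O)CC(C)C)c(O)c1C` gives 614 nM. Compound 2 `CCCC(=O)c1ccc(OCCCCOc2cc(C(=O)O)ccc2OC)c(C)c1O` gives 496 nM, and compound 3 `COc1ccc(C(=O)O)cc1OCCCCOc1ccc(C(=O)CC(C)C)c(O)c1C` gives 737 nM. The difference between the core of compound 1 and the core of compound 2 is not broken down here; their two values lie within the scatter of each other.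

Compound 3 arises from compound 2 by methyl in place of hydrogen on a saturated chain carbon bound to two saturated chain carbons, and that step reads a 1.5-fold higher number from compound 2 to compound 3 (0.17 log units; within the scatter).

Compound 4 `COc1cc(C(=O)O)ccc1OCCCCOc1ccc(C(=O)CC(C)(C)C)c(O)c1C` is not yet measured. It arises from compound 1 by methyl in place of hydrogen on a saturated chain carbon bound to three saturated chain carbons. This is the same kind of change as from compound 2 to compound 3, not the same: there the place was a saturated chain carbon bound to two saturated chain carbons, here it is one bound to three.

Resting on compound 1 with 614 nM and on a 1.5-fold higher number from compound 2 to compound 3 (0.17 log units; within the scatter), a small step is expected, a 1.3-fold higher number from compound 1 to compound 4 (0.11 log units; within the scatter), probably within the scatter. For compound 4 the estimated value in this assay is 800 nM, expected between 400 nM and 1700 nM.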

Compound 4, half-maximal effective concentration: 310 nM
Estimate against measurement, compound 4: 2.6-fold (0.41 log units) above; the measured number lies below the stated range.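

In this assay a methyl in place of hydrogen on a saturated chain carbon bound to three saturated chain carbons gives a 2.0-fold lower number from compound 1 to compound 4 (0.30 log units; within the scatter) and so, read alone, no clear change. Set beside the earlier step, however, it shows that this kind of methyl addition does not carry from one core to another as a fixed shift: the same change on two cores in this assay, a 1.5-fold higher number (0.17 log units; within the scatter) from compound 2 to compound 3 and a 2.0-fold lower number (0.30 log units; within the scatter) from compound 1 to compound 4, 2.9-fold (0.47 log units) apart, beyond the scatter of two such steps. What this does not show is the source of the gap: the two steps differ both in the core and in the carbon that takes the methyl, bound to two saturated chain carbons in one case and to three in the other, and a single pair of steps cannot separate these.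

The compounds shown leave open how the change from isobutyl to neopentyl reads on the core of compound 3, which would hold the carbon fixed while the core changes. They also leave open how a longer chain, such as hexyl, would read on the ketone.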